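Swapping a saturated ring for a pyrazole at the amine

This account rests on a few compounds, and the source may have more. Where it says the series, first, only, none or still open, it means among the compounds named here.

Compound 1 `C[C@H](Nc1c(C(N)=O)nnc2ccc(-c3ccc(OCCCN(C)C)nc3)cc12)C1CCOCC1`, compound 2 `C[C@H](Nc1c(C(N)=O)nnc2ccc(-c3ccc(OCCCN(C)C)nc3)cc12)c1ccn(C)n1` and compound 3 `C[C@H](Nc1c(C(N)=O)nnc2ccc(-c3ccc(OCCCN4CCCC4)nc3)cc12)C1CCOCC1` share one core and were measured in a physicochemical assay for lipophilicity, using the shake flask method, measured as octanol-water partition, with a stated time of 30 min, at pH 7.4; on this read-out lower numbers stand for lower lipophilicity and higher numbers for higher lipophilicity. In this assay compound 1 gives 1.9, compound 2 gives 1.7 and compound 3 gives 1.9. Compound 2 differs from compound 1 by 1-methyl-1H-pyrazol-3-yl in place of oxan-4-yl on a saturated chain carbon bound to a nitrogen on an aromatic ring and a saturated chain carbon, and that change made a step of a number 0.20 log units lower from compound 1 to compound 2 (within the scatter). Compound 3 differs from compound 1 by pyrrolidin-1-yl in place of dimethylamino on a saturated chain carbon, three bonds along the chain from an oxygen on an aromatic ring, with a step of no change at the digits printed from compound 1 to compound 3 (within the scatter). Compound 4 `C[C@H](Nc1c(C(N)=O)nnc2ccc(-c3ccc(OCCCN4CCCC4)nc3)cc12)c1ccn(C)n1` has not yet been measured in this assay. It is related to compound 3 by 1-methyl-1H-pyrazol-3-yl in place of oxan-4-yl on a saturated chain carbon bound to a nitrogen on an aromatic ring and a saturated chain carbon, the same change that turns compound 1 into compound 2, made on a core that differs only by the pyrrolidin-1-yl group in place of dimethylamino. The step is therefore expected to be about a number 0.20 log units lower from compound 3 to compound 4 (within the scatter), resting on the step from compound 1 to compound 2 of a number 0.20 log units lower from compound 1 to compound 2 (within the scatter). The value of compound 4 is thus estimated at 1.7, probably between 1.4 and 2.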

Compound 4, distribution coefficient: 1.8
For compound 4 the middle estimate is 0.10 log units below the measured one, and the stated range covers the measured number.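

In this assay, 1-methyl-1H-pyrazol-3-yl in place of oxan-4-yl gives a number 0.10 log units lower from compound 3 to compound 4 (within the scatter) on the core carrying pyrrolidin-1-yl, and a number 0.20 log units lower from compound 1 to compound 2 (within the scatter) on the core carrying dimethylamino. On both cores, then, this change produces no step larger than the usual differences between repeated measurements, and the other change gives the same picture, with pyrrolidin-1-yl in place of dimethylamino giving a number 0.10 log units higher from compound 2 to compound 4 (within the scatter) on the core carrying the pyrazole. This supports carrying the change across these two cores only as a step too small to read, and it does not show a step of fixed size or a difference between the cores, while nothing measured here offers an explanation for the numbers.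

The compounds shown cover only two groups at each of the two places. Going by these compounds, it stays open whether the change would stay this small with morpholin-4-yl in place of pyrrolidin-1-yl, or with a carboxylic acid or a longer chain on the core.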